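The compounds below may be only part of what the source reports. "The series", "measured", "known", "first", "only" and "open" are said of these compounds alone.

Measured to date in an assay on nucleic acid for binding affinity to Salmon testes DNA (Salmonidae), tested at 10 uM; a higher number here means that the compound stabilises the target more against heat, a lower number that the compound stabilises the target less:
compound 1 `CC(C)CCc1sc(NC(=O)c2cc(NC(=O)c3cc(NC(=N)c4cccc(Cl)c4)cn3C)cn2C)nc1C(=O)NCCCN(C)C` gives 5 degrees C
compound 2 `CC(C)CCn1cc(NC(=O)c2cc(NC(=O)c3cc(NC(=N)c4ccccc4)cn3C)cn2C)cc1C(=O)NCCCN(C)C` gives 8 degrees C
compound 3 `CN(C)CCCNC(=O)c1cc(NC(=O)c2cc(NC(=O)c3cc(NC(=N)N)cn3C)cn2C)cn1C` gives 5 degrees C

Compound 3 stands level with compound 1 at the digits shown, the two together at the low end of the three numbers; compound 2 lies higher, and that gap is beyond the scatter. Compound 4 `COc1cccc(C(=N)Nc2cc(C(=O)Nc3cc(C(=O)Nc4cc(C(=O)NCCCN(C)C)n(C)c4)n(C)c3)n(C)c2)c1` is still to be measured in this assay. It differs from compound 3 in one place: 3-methoxyphenyl in place of amino on a carbon with a double bond to nitrogen. For the measured compounds named here, no step between measured compounds covers this exchange alone; compound 1 and compound 2 both lack the amino of compound 3 but differ from it in more than one place, so their values are only a loose guide. The expected step of a number 1.0 degrees C higher from compound 3 to compound 4 (within the scatter) is small and upward, within the scatter. Compound 4 is expected to give 6 degrees C, with a range from 3 degrees C to 9 degrees C.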

Compound 4, shift of the target's melting temperature: 11 degrees C
Compound 4: the middle estimate sits 5.0 degrees C below what was measured, outside the stated range (above it).
By their numbers in this assay, from the lowest: compounds 1 and 3 (each within the scatter of the next); then compound 2; then compound 4.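

On a carbon with a double bond to nitrogen, 3-methoxyphenyl in place of amino gives a number 6.0 degrees C higher from compound 3 to compound 4 (beyond the scatter) in this assay. For the compounds shown here, this is the first single-place step, and it shows that this position accepts a much larger ring-bearing group with a gain in the read-out. Nothing on hand explains the size of this step.

On these data alone, whether the gain comes from the aromatic ring or from its methoxy remains open. So does how a pyridine ring or a carboxylic acid would read at this position.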